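Buffer Stability of Three Ester-Linked Analogues

The source may hold more compounds than are shown below. What is called first, only, known or untested is meant among the compounds shown, and "the series" means these compounds.

Compound 1 `C[C@@H](O)[C@H]1C(=O)N2C(C(=O)OCOC(=O)C(C)(C)C)=C(S[C@@H]3CN[C@H](C(=O)Nc4cccc(C(=O)O)c4)C3)[C@H](C)[C@H]12`: > 95%
Compound 2 `C[C@@H](O)[C@H]1C(=O)N2C(C(=O)OCOC(=O)C3CCCCC3)=C(S[C@@H]3CN[C@H](C(=O)Nc4cccc(C(=O)O)c4)C3)[C@H](C)[C@H]12`: > 95%

In a physicochemical assay for metabolic stability, read by LC-MS, in phosphate buffer, with a stated time of 3 h, at pH 7.4, tested at 50 uM (on this read-out higher numbers stand for a more stable compound and lower numbers for a less stable compound), compound 1 reaches > 95%, which is a limit of the assay rather than a number. Compound 2 likewise reaches > 95% in this assay, again a limit. For the measured compounds named here, the single measured step, a step that the two limits leave unreadable from compound 1 to compound 2, cannot be read in size, since (the limit of > 95% in this assay, at which 2 of the 2 values shown sit). Compound 2 thus stands at the top of what this read-out reports, with nothing that sets it apart from compound 1.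

Compound 3 `CCOC(=O)C1=C(S[C@@H]2CN[C@H](C(=O)Nc3cccc(C(=O)O)c3)C2)[C@H](C)[C@@H]2[C@@H]([C@@H](C)O)C(=O)N12` differs from compound 2 by methyl in place of (cyclohexylcarbonyl)oxy on a saturated chain carbon bound to an oxygen next to a carbonyl group. Going by the values given here, no measured step covers this kind of change: the one step at hand, a step that the two limits leave unreadable from compound 1 to compound 2, swaps one acyl group for another and says nothing about removing the (cyclohexylcarbonyl)oxy unit altogether. With both measured compounds at the limit, no direction can be drawn from them. Compound 3 is therefore expected to give 95% in this assay, between 85% and 100%. The expected step of a number no higher from compound 2 to compound 3 (the limit leaves the size open) is estimated to lie within the scatter.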

Compound 3, percent of the compound remaining: > 95%
Compound 3: no number, only a limit; the forecaster's own chance of this, stated with the estimate: 70%; the middle value lies on the limit itself.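

In this assay, for the compounds shown here, no step among compound 1, compound 2 and compound 3 can be read in size, because all three stop at the same limit: (the limit of > 95% in this assay, at which 3 of the 3 values shown sit). The compounds shown leave open whether swapping the ((tert-butyl)carbonyl)oxy, (cyclohexylcarbonyl)oxy and methyl ends changes the percent remaining at all, since any real difference would stay hidden behind that limit.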